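The compounds below may be only part of what the source reports. "The series", "measured", "known", "first", "only" and "open" are said of these compounds alone.

Of the compounds shown here, three with a shared core have been measured in a functional assay on aorta for antagonist activity at Alpha-1D adrenergic receptor (Rattus norvegicus); on this read-out lower numbers stand for tighter binding and higher numbers for weaker binding. Compound 1 `COc1ccccc1N1CCN(CCCNc2ncccc2C(=O)NC(C)(C)C)CC1` gives 10 nM, compound 2 `COc1ccccc1N1CCN(CCCSc2ccccc2C(=O)N(C)C)CC1` gives 12.6 nM, and compound 3 `CN(C)C(=O)c1cccnc1NCCCN1CCN(c2ccccc2)CC1` gives 15.9 nM. Compound 3 holds the highest of the three numbers, yet its gap to compound 2 and to compound 1 both lie within the usual scatter, so the three are indistinguishable on this evidence.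

Compound 4 `COc1cc(C)ccc1N1CCN(CCCNc2ncccc2C(=O)N(C)C)CC1` has not been measured. Relative to compound 3 the change is 2-methoxy-4-methylphenyl in place of phenyl on an amine nitrogen in a ring. Going by the values given here, no measured pair isolates this change, so only a cautious expectation is possible: the step from compound 3 to compound 4 is expected to be a 2.0-fold lower number from compound 3 to compound 4 (0.30 log units; within the scatter), essentially none beyond the scatter. Compound 4 is therefore expected to give about 8 nM, with a range from 3 nM to 25 nM.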

Compound 4, dissociation constant: 39.8 nM
Estimate against measurement, compound 4: 5.0-fold (0.70 log units) below; measured number outside the range, above it.
By their numbers in this assay, from the lowest: compounds 1, 2 and 3 (each within the scatter of the next); then compound 4.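

Going by these compounds alone, on the amine nitrogen in the ring, 2-methoxy-4-methylphenyl in place of phenyl gives a 2.5-fold higher number from compound 3 to compound 4 (0.40 log units; beyond the scatter) in this assay, the first step here that isolates one change. It shows that this position responds to substitution on the phenyl, and that this larger group, which adds a hydrogen-bond acceptor, weakens binding modestly rather than tightening it. No evidence here accounts for the shift. On these data alone, the methoxy and the methyl enter together, and their separate shares in the step stay open. As far as these compounds go, how a chlorine or a hydroxyl on the phenyl would read also stays open.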